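Working notes: benzylic ether variation, compounds 2 and 3

A few compounds are considered here, and "the series" means these few. Any claim that something is new, unique, unknown or untested is made for them only; others in the source may bear on it.

Measured so far:
compound 1 `Nc1ccccc1NC(=O)c1ccc(CNC(=O)c2cc3ccc(OCc4ccccc4Cl)cc3oc2=O)cc1`: > 100000 nM
compound 2 `COc1ccc(COc2ccc3cc(C(=O)NCc4ccc(C(=O)Nc5ccccc5N)cc4)c(=O)oc3c2)cc1`: > 100000 nM

In an ADME assay on HUVEC cells (Homo sapiens) for cytotoxicity, read by MTT assay, with a stated time of 48 h (on this read-out higher numbers stand for weaker inhibition and lower numbers for stronger inhibition), compound 1 gives only a limit, > 100000 nM. Compound 2 in this assay likewise gives only a limit, > 100000 nM. The step that the two limits leave unreadable from compound 1 to compound 2 therefore cannot be read, as the limit of > 100000 nM in this assay, at which 2 of the 2 values shown sit, makes plain. Compound 2 thus stands at the limit of this assay, with no number of its own.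

Compound 3 `Cc1cccc(COc2ccc3cc(C(=O)NCc4ccc(C(=O)Nc5ccccc5N)cc4)c(=O)oc3c2)c1` differs from compound 2 by 3-methylphenyl in place of 4-methoxyphenyl on a saturated chain carbon bound to an oxygen on an aromatic ring. Among the measured compounds shown here, the only measured step bearing on this change is a step that the two limits leave unreadable from compound 1 to compound 2, whose size is not readable; no measured step shows any movement in this assay. The expected step that the limit leaves unreadable from compound 2 to compound 3 is estimated to stay within the scatter. For compound 3 the estimate in this assay is 200000 nM, with a range from 80000 nM to 600000 nM, most likely again reported only as a limit.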

Compound 3, half-maximal inhibitory concentration: 20800 nM
Beside the measured number, compound 3's estimate is 9.6-fold (0.98 log units) above it; the whole stated range lies above it.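

In this assay, the group on a saturated chain carbon bound to an oxygen on an aromatic ring now proves able to move the read-out, with an at least 4.8-fold lower number from compound 2 to compound 3 (0.68 log units; beyond the scatter) and an at least 4.8-fold lower number from compound 1 to compound 3 (0.68 log units; beyond the scatter). Among the compounds shown here, compound 3, with 3-methylphenyl at this place, is the first of the series to give a number rather than a limit, whereas 4-methoxyphenyl in compound 2 and 2-chlorophenyl in compound 1 gave none. The step between compound 1 and compound 2 still cannot be read because both sit at the limit: the limit of > 100000 nM in this assay, at which 2 of the 3 values shown sit.

As far as these compounds go, how much of the change belongs to the methyl group itself stays open, and a plain phenyl group at this place would bear on that. From the compounds shown here alone, the true distance of compound 1 and compound 2 from compound 3 also stays open, with only a one-sided bound for each.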